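Compound 2 to compound 4: isobutyl for 4-fluorophenyl

The source may report more compounds than this note shows. Statements on the series, on what has been measured and on what is new or still open speak of the compounds shown alone.

In a functional assay on HCT-116 cells (Homo sapiens) for cytotoxicity, read by CellTiter-Glo, with a stated time of 5 days (on this read-out lower numbers stand for stronger inhibition and higher numbers for weaker inhibition), compound 2 (`Cc1cc(Nc2nn(-c3ccc(F)cc3)c(=O)c3ccccc23)n[nH]1`) gives 800 nM and lies within the scatter of compound 1 (`COc1ccc(-n2nc(Nc3cc(C)[nH]n3)c3ccccc3c2=O)cc1`) at 700 nM in this small set. Compound 3 (`Cc1cc(Nc2nn(Cc3ccc(S(C)(=O)=O)cc3)c(=O)c3ccccc23)n[nH]1`) reads 1700 nM as a higher number than compound 2. Compound 4 (`Cc1cc(Nc2nn(CC(C)C)c(=O)c3ccccc23)n[nH]1`) has isobutyl in place of 4-fluorophenyl on an aromatic nitrogen. Going by the values given here, the one measured step, a 1.1-fold higher number from compound 1 to compound 2 (0.06 log units; within the scatter) for fluoro in place of methoxy on an aromatic carbon, keeps the aromatic ring and says little about losing it. Compound 3 at 1700 nM is the nearest guide, though a single one. The expected size is a 2.3-fold higher number from compound 2 to compound 4 (0.35 log units; beyond the scatter) toward a higher number. Compound 4 is estimated at 1800 nM with a range from 700 nM to 4500 nM for now.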

Compound 4, half-maximal inhibitory concentration: 1100 nM
Estimate against measurement, compound 4: 1.6-fold (0.21 log units) above, and the stated range covers the measured number.
By their numbers in this assay, from the lowest: compounds 1, 2, 4 and 3 (each within the scatter of the next, the first and the last beyond it).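

In this assay replacing the aromatic ring on the aromatic nitrogen with isobutyl gives a 1.4-fold higher number from compound 2 to compound 4 (0.14 log units; within the scatter) and a 1.6-fold higher number from compound 1 to compound 4 (0.20 log units; within the scatter). Going by these compounds alone, the earlier step kept that ring, so these are the first data showing that a ring-free group can sit at this position without a change beyond the scatter. No supporting measurement is available to explain this result. As far as these compounds go, whether an amine, a carboxylic acid or a longer chain on this nitrogen would stay within the same range remains open.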